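The source may hold more compounds than are shown below. What is called first, only, known or untested is meant among the compounds shown, and "the series" means these compounds.

Measured so far in a functional assay on MCF7 cells (Homo sapiens) for cytotoxicity, read by sulforhodamine B assay; a higher number here means a weaker inhibitor, a lower number a stronger inhibitor:
- compound 1 `O=C(c1cccnc1)c1cc2c(-c3cccnc3)nn(-c3ccccc3)c2[nH]c1=O`: 10.1 ug/mL
- compound 2 `N#Cc1cc2c(-c3cccnc3)nn(-c3ccccc3)c2[nH]c1=O`: 3 ug/mL

Among the measured compounds shown here, compound 2 stands at the lowest of the two numbers in this assay; the only neighbour is compound 1, and the step of a 3.4-fold lower number from compound 1 to compound 2 (0.53 log units; beyond the scatter) separates them. Compound 3 `Cc1ccc(C(=O)c2cc3c(-c4cccnc4)nn(-c4ccccc4)c3[nH]c2=O)cc1` is not yet measured. It differs from compound 2 in one place: (4-methylphenyl)carbonyl in place of cyano on an aromatic carbon. For the measured compounds named here, the single measured step that bears on this change is a 3.4-fold lower number from compound 1 to compound 2 (0.53 log units; beyond the scatter), in which an aryl carbonyl gave way to cyano and the number fell. Compound 3 runs that exchange in the opposite direction, so the expectation is a rise of similar size, a 2.7-fold higher number from compound 2 to compound 3 (0.43 log units; beyond the scatter). Going by the values given here, no measured pair shows what a 4-methylphenyl carbonyl does in place of a (pyridin-3-yl)carbonyl, so that part of the change is unanchored and widens the range. Compound 3 is therefore estimated at 8 ug/mL, expected between 3 ug/mL and 20 ug/mL.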

Compound 3, half-maximal inhibitory concentration: 9.9 ug/mL
Estimate against measurement, compound 3: 1.2-fold (0.09 log units) below; the range from low to high includes it.
By their numbers in this assay, from the lowest: compound 2; then compounds 3 and 1 (each within the scatter of the next).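

In this assay the step of a 1.0-fold lower number from compound 1 to compound 3 (0.01 log units; within the scatter) shows that 4-methylphenyl in place of pyridin-3-yl on the carbonyl carbon does not separate the two aryl carbonyl compounds. The step of a 3.3-fold higher number from compound 2 to compound 3 (0.52 log units; beyond the scatter) therefore places compound 2, with its cyano group, apart from both aryl carbonyl compounds at this aromatic carbon, whichever of these two aryl groups the carbonyl carries. Nothing on hand accounts for this difference.

As far as these compounds go, whether the lower number belongs to the nitrile itself or simply to the absence of an aryl carbonyl stays open; a hydrogen, a carboxylic acid or a primary amide at this carbon would help separate the two. Also open, from the compounds shown here alone, is whether a short alkyl chain on the carbonyl would behave like these two aryl groups.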